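A few compounds are considered here, and "the series" means these few. Any claim that something is new, unique, unknown or untested is made for them only; others in the source may bear on it.

Measured so far:
- compound 1, `CC(C(=O)NCc1ccc(Cl)c(Cl)c1)c1ccc(NS(C)(=O)=O)c(F)c1`: 115 nM
- compound 2, `CC(C)c1ccc(CNC(=O)C(C)c2ccc(NS(C)(=O)=O)c(F)c2)cc1`: 144 nM
- compound 3, `CC(C(=O)NCc1ccc(C2CC2)cc1)c1ccc(NS(C)(=O)=O)c(F)c1`: 55.5 nM

Among these three, compound 3 gives the lowest number in a functional assay on CHO cells for antagonist activity at transient receptor potential cation channel subfamily V member 1 (Rattus norvegicus) (a lower number here means a stronger inhibitor, a higher number a weaker inhibitor), and its steps to both neighbours lie beyond the scatter: a 2.1-fold lower number from compound 1 to compound 3 (0.32 log units; beyond the scatter) and a 2.6-fold lower number from compound 2 to compound 3 (0.41 log units; beyond the scatter), so it is the strongest inhibitor of the three. Compound 4, `CC(C(=O)NCCCc1ccc(Cl)cc1)c1ccc(NS(C)(=O)=O)c(F)c1`, has not yet been tested. It differs from compound 3 in one place: 2-(4-chlorophenyl)ethyl in place of 4-cyclopropylphenyl on a saturated chain carbon bound to an amide-type nitrogen. Going by the values given here, two measured steps touch this same place. The change from 3,4-dichlorophenyl to 4-cyclopropylphenyl and the change from 4-isopropylphenyl to 4-cyclopropylphenyl were both modest, and in each case the 4-cyclopropylphenyl compound gave the lower number. Among the compounds with values here, removing the 4-cyclopropylphenyl therefore seems more likely to raise the number than to lower it, but no measured step covers the 2-(4-chlorophenyl)ethyl group, so the size is uncertain. The expected step is a 2.7-fold higher number from compound 3 to compound 4 (0.43 log units; beyond the scatter), a modest weakening. Compound 4 is estimated at 150 nM, with a range from 50 nM to 450 nM.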

Compound 4, inhibition constant: 135 nM
Beside the measured number, compound 4's estimate is 1.1-fold (0.05 log units) above it; measured number inside the range.
By their numbers in this assay, from the lowest: compound 3; then compounds 1, 4 and 2 (each within the scatter of the next).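

In this assay, the 2-(4-chlorophenyl)ethyl group performs like two of the earlier groups at this position: a 1.1-fold lower number from compound 2 to compound 4 (0.03 log units; within the scatter) and a 1.2-fold higher number from compound 1 to compound 4 (0.07 log units; within the scatter) both leave compound 4 level with the 4-isopropylphenyl and 3,4-dichlorophenyl compounds. Only the 4-cyclopropylphenyl group stands apart, with a 2.4-fold higher number from compound 3 to compound 4 (0.39 log units; beyond the scatter), so compound 3 remains the strongest inhibitor of the four, even though the two exchanged groups have the same count of 9 heavy atoms. Nothing available explains why the 4-cyclopropylphenyl group gives this difference.

The compounds shown leave open how a longer chain carrying the 4-chlorophenyl ring would compare at this position. They also leave open what an amine or a carboxylic acid on the ring would do to the number.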